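Swapping methyl for methoxy: what cytotoxicity to expect

The source may report more compounds than this note shows. Statements on the series, on what has been measured and on what is new or still open speak of the compounds shown alone.

Compound 1, `Cc1cc(-c2ccc(F)nc2F)nn(Cc2ccc(Cl)cc2)c1=O` — in an ADME assay on HepG2 2.2.15 cells (Homo sapiens) for cytotoxicity, read by MTT assay, with a stated time of 8 days (a lower number here means that less compound is tolerated, a higher number that more compound is tolerated), compound 1 gives 83800 nM.
Compound 2, `CC(=O)Nc1ccc(-c2nn(Cc3ccc(C#N)cc3)c(=O)c3ccccc23)c(F)n1` — in this assay compound 2 gives > 100000 nM, which is a limit of the assay and not a number.
Compound 3, `Cc1ccc(-c2nn(Cc3ccc(C#N)cc3)c(=O)c3ccccc23)c(F)n1` — in this assay compound 3 gives > 100000 nM, again a limit rather than a number.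

Among the measured compounds shown here, compound 1 therefore stands as the only measured number among the three; the other two values sit at the limit of > 100000 nM in this assay, at which 2 of the 3 values shown sit. For the measured compounds named here, the single step between measured compounds, a step that the two limits leave unreadable from compound 2 to compound 3, has both ends at limits and so offers no readable size. Compound 4, `COc1cc(-c2ccc(F)nc2F)nn(Cc2ccc(Cl)cc2)c1=O`, is compound 1 with methoxy in place of methyl on an aromatic carbon. Going by the values given here, no measured step bears on this change, so no shift beyond the usual scatter is expected. Compound 4 is estimated at 90000 nM, with a range from 40000 nM to 200000 nM. The expected step of a 1.1-fold higher number from compound 1 to compound 4 (0.03 log units; within the scatter) is thus small.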

Compound 4, half-maximal cytotoxic concentration: 92200 nM
Beside the measured number, compound 4's estimate is 1.0-fold (0.01 log units) below it; the measured number falls inside the stated range.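

In this assay, putting methoxy in place of methyl gives a 1.1-fold higher number from compound 1 to compound 4 (0.04 log units; within the scatter), so at this position, opposite the ring nitrogen, the extra oxygen leaves the tolerated concentration unchanged within the usual scatter. This is the first step among the compounds shown that can be read, since the earlier step has limits at both ends. Nothing shown offers a reason for this result.

On these data alone, whether an amine, a carboxylic acid or a longer chain at this position would behave the same stays open. So does whether methoxy would do so on a core other than that of compound 1.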